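Methyl on the amine nitrogen: a small change to compound 1

This account rests on a few compounds, and the source may have more. Where it says the series, first, only, none or still open, it means among the compounds named here.

Compound 1 `Cc1ccc(N2CCN(C(=O)[C@@H]3CN(C4CCOCC4)C[C@H]3c3ccc(Cl)cc3)CC2)c([C@@H](NC(=O)CN)C(C)C)c1`: 114%
Compound 2 `CC(=O)N1C[C@@H](C(=O)N2CCN(c3ccc(C)cc3[C@@H](NC(=O)CCN(C)C)C(C)C)CC2)[C@H](c2ccc(Cl)cc2)C1`: 100%
Compound 3 `CC(C)[C@H](NC(=O)CCN(C)C)c1cccc(F)c1N1CCN(C(=O)[C@@H]2CN(C(C)C)C[C@H]2c2ccc(Cl)cc2)CC1`: 103%

Of the compounds shown here, three sharing one core have been measured in a functional assay on CHO cells with Melanocortin receptor 4 (Homo sapiens) as the target, read by cAMP accumulation; on this read-out higher numbers stand for larger maximal responses and lower numbers for smaller maximal responses. Compound 1 gives 114%, the largest maximal response of the three. Compound 3 gives 103%, and compound 2 gives 100%; both lie beyond the usual scatter below compound 1, so compound 1 stands clearly on top of this small set. No two of these compounds differ in only one place, so no single step between measured compounds can be read off.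

Compound 4 `CNCC(=O)N[C@H](c1cc(C)ccc1N1CCN(C(=O)[C@@H]2CN(C3CCOCC3)C[C@H]2c2ccc(Cl)cc2)CC1)C(C)C` has not yet been measured. It differs from compound 1 in one spot: methyl in place of hydrogen on an amine nitrogen. This is the smallest possible addition, a single carbon, at the end of the chain that carries the amine.

Going by the values given here, with no measured step of this kind to lean on, the expectation rests on the size of the change alone. Compound 4 is expected to stay close to compound 1, with a step of a number 4 percentage points lower from compound 1 to compound 4 (within the scatter) that falls within the scatter, in no firm direction. Compound 4 is therefore estimated at 110%, likely between 95% and 125%.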

Compound 4, intrinsic activity: the largest response reached, in percent of the reference agonist's: 84%
Beside the measured number, compound 4's estimate is 26 percentage points above it; measured number outside the range, below it.
By their numbers in this assay, from the lowest: compound 4; then compounds 2 and 3 (each within the scatter of the next); then compound 1.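

The amine nitrogen at the end of the chain in compound 1 is sensitive to even a very small change: in this assay, adding one methyl there gives a number 30 percentage points lower from compound 1 to compound 4 (beyond the scatter). Going by these compounds alone, this is the first comparison in the set in which only one place differs, so the drop can be tied to this single added carbon rather than to changes elsewhere in the molecule. Nothing available explains why so small an addition lowers the maximal response this far.

The compounds shown leave open how larger groups on this same nitrogen, such as ethyl, isopropyl or cyclopropyl, would compare with methyl. They also do not show whether an acetyl group there, which would turn the amine into an amide, would lower the response in the same way.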